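A few compounds are considered here, and "the series" means these few. Any claim that something is new, unique, unknown or untested is made for them only; others in the source may bear on it.

Compound 3 `N[C@]1(C(=O)O)[C@H]2[C@@H](C[C@H]1OCc1cc(F)ccc1F)[C@]2(F)C(=O)O` gives 14.4 nM in an assay on CHO cells for binding affinity to metabotropic glutamate receptor 2 (Rattus norvegicus) (on this read-out higher numbers stand for weaker inhibition and lower numbers for stronger inhibition), the highest of the three numbers measured. Compound 1 `N[C@]1(C(=O)O)[C@H]2[C@@H](C[C@H]1OCc1cccc(Cl)c1)[C@]2(F)C(=O)O` gives 3.28 nM, and compound 2 `N#Cc1cccc(CO[C@@H]2C[C@@H]3[C@H]([C@]2(N)C(=O)O)[C@@]3(F)C(=O)O)c1` gives 2.94 nM. Compound 4 `N[C@]1(C(=O)O)[C@H]2[C@@H](C[C@H]1OCc1c(F)cccc1F)[C@]2(F)C(=O)O` differs from compound 3 by 2,6-difluorophenyl in place of 2,5-difluorophenyl on a saturated chain carbon bound to an oxygen on a saturated carbon. Among the compounds with values here, no measured step rearranges fluorines on this ring; the nearest guidance is that changing the aryl group moved the number modestly, a 4.4-fold higher number from compound 1 to compound 3 (0.64 log units; beyond the scatter) and a 4.9-fold higher number from compound 2 to compound 3 (0.69 log units; beyond the scatter), so the aryl group does affect this read-out. With nothing closer to rest on, the step of a 1.0-fold higher number from compound 3 to compound 4 (0.02 log units; within the scatter) is expected to stay near zero, with wide uncertainty. Compound 4 is therefore estimated at 15 nM, within a range of 5 nM to 45 nM.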

Compound 4, inhibition constant: 7.02 nM
Compound 4: the middle estimate sits 2.1-fold (0.33 log units) above what was measured, within the range that was stated.
By their numbers in this assay, from the lowest: compounds 2 and 1 (each within the scatter of the next); then compound 4; then compound 3.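

In this assay, putting 2,6-difluorophenyl in place of 2,5-difluorophenyl, with the same atoms joined differently, gives a 2.1-fold lower number from compound 3 to compound 4 (0.31 log units; beyond the scatter) and shows that where the fluorines sit on this ring matters, not only which aryl group is present. The 3-cyanophenyl and 3-chlorophenyl groups still give lower numbers: a 2.4-fold higher number from compound 2 to compound 4 (0.38 log units; beyond the scatter) and a 2.1-fold higher number from compound 1 to compound 4 (0.33 log units; beyond the scatter) both lie beyond the usual scatter. Nothing available explains why the fluorine pattern shifts the number.

Still open, going by these compounds, is how a phenyl ring carrying an amine or a carboxylic acid would fare at this place, and whether a longer chain there would hold the number.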